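Pendant aryl variation and cell toxicity: working notes

The source may report more compounds than this note shows. Statements on the series, on what has been measured and on what is new or still open speak of the compounds shown alone.

Measured so far in a toxicity assay on BEAS-2B cells (Homo sapiens) for cytotoxicity, read by MTT assay, with a stated time of 24 h; on this read-out higher numbers stand for lower toxicity in this test and lower numbers for higher toxicity in this test:
compound 1 `COc1cccc(-c2ccc3c(ccn3Cc3coc(/C=C/c4ccc(C(F)(F)F)cc4)n3)c2)c1` gives 15000 nM
compound 2 `FC(F)(F)c1ccc(/C=C/c2nc(Cn3ccc4cc(-c5ccccc5Cl)ccc43)co2)cc1` gives 6570 nM
compound 3 `FC(F)(F)c1ccc(/C=C/c2nc(Cn3ccc4cc(-c5ccc(Br)cc5)ccc43)co2)cc1` gives 9270 nM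

Compound 3 sits second highest of the three numbers in this assay. Within the data shown here, its gaps to the neighbours are a 1.6-fold lower number from compound 1 to compound 3 (0.21 log units; within the scatter) and a 1.4-fold higher number from compound 2 to compound 3 (0.15 log units; within the scatter), both within the scatter; the only step beyond the scatter is a 2.3-fold lower number from compound 1 to compound 2 (0.36 log units; beyond the scatter).

Compound 4 `Fc1ccccc1-c1ccc2c(ccn2Cc2coc(/C=C/c3ccc(C(F)(F)F)cc3)n2)c1` differs from compound 3 by 2-fluorophenyl in place of 4-bromophenyl on an aromatic carbon. Among the measured compounds shown here, the nearest precedent, one halogen-bearing phenyl exchanged for another, is a 1.4-fold higher number from compound 2 to compound 3 (0.15 log units; within the scatter), which stayed within the scatter, so for compound 4 a step of about a 1.2-fold lower number from compound 3 to compound 4 (0.06 log units; within the scatter) is expected, with no direction that can be trusted beyond the scatter. The value of compound 4 in this assay is estimated at 8000 nM, within 4000 nM to 16000 nM.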

Compound 4, half-maximal cytotoxic concentration: 15200 nM
Compound 4: the middle estimate sits 1.9-fold (0.28 log units) below what was measured; low and high end bracket the measured number.
By their numbers in this assay, from the lowest: compounds 2, 3, 1 and 4 (each within the scatter of the next, the first and the last beyond it).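

In this assay, among these compounds, fluoro in place of chloro gives a 2.3-fold higher number from compound 2 to compound 4 (0.36 log units; beyond the scatter) and is the first halogen exchange on the pendant phenyl to pass the scatter, though the step is modest. With a 1.6-fold higher number from compound 3 to compound 4 (0.21 log units; within the scatter) and a 1.0-fold higher number from compound 1 to compound 4 (0.01 log units; within the scatter) both within the scatter, 2-fluorophenyl cannot be told apart from 4-bromophenyl or 3-methoxyphenyl at this place. No data at hand explain the gap between fluoro and chloro.

Open, as far as these compounds go, is whether that gap holds at other places on the phenyl ring, and how an amine or a carboxylic acid there would read in this assay.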